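Nitrophenyl position change on the amide-type nitrogen

The source may report more compounds than this note shows. Statements on the series, on what has been measured and on what is new or still open speak of the compounds shown alone.

In a functional assay on CRL2813 cells (Homo sapiens) for cytotoxicity, read by sulforhodamine B assay, with a stated time of 5 days; on this read-out higher numbers stand for weaker inhibition and lower numbers for stronger inhibition:
compound 1 `O=C(Nc1cccc(C(F)(F)F)c1)N[C@H]1CC[C@H](Oc2ccc(C(F)(F)F)cc2)CC1` gives 460 nM
compound 2 `O=C(Nc1ccc([N+](=O)[O-])cc1)N[C@H]1CC[C@H](Oc2ccc(F)cc2)CC1` gives 2300 nM
compound 3 `O=C(Nc1cccc(C(F)(F)F)c1)N[C@H]1CC[C@H](Oc2ccccc2C(F)(F)F)CC1` gives 1400 nM

Compound 2 gives the highest of the three numbers. Compound 2 and compound 3 lie within the scatter of each other; compound 1 gives a lower number than compound 2, beyond the scatter.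

Compound 4 `O=C(Nc1cccc([N+](=O)[O-])c1)N[C@H]1CC[C@H](Oc2ccc(F)cc2)CC1` differs from compound 2 in one place: 3-nitrophenyl in place of 4-nitrophenyl on an amide-type nitrogen. For the measured compounds named here, the one measured step, a 3.0-fold higher number from compound 1 to compound 3 (0.48 log units; beyond the scatter), moves a group to another ring position, but on the ring attached to an oxygen on a saturated carbon, not on the amide-type nitrogen. Going by the values given here, no measured step tests a position change on the nitrophenyl. Compound 4 is therefore expected to give a number close to that of compound 2, with no confident direction; the expected step is a 1.1-fold higher number from compound 2 to compound 4 (0.04 log units; within the scatter). The estimate for compound 4 is 2500 nM, range 900 nM to 7000 nM.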

Compound 4, half-maximal inhibitory concentration: 6700 nM
The estimate for compound 4 lay 2.7-fold (0.43 log units) below the measured number, and the stated range covers the measured number.
By their numbers in this assay, from the lowest: compound 1; then compounds 3 and 2 (each within the scatter of the next); then compound 4.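

The ring on the amide-type nitrogen responds to position: 3-nitrophenyl in place of 4-nitrophenyl gives a 2.9-fold higher number from compound 2 to compound 4 (0.46 log units; beyond the scatter) in this assay, so the nitro position is not neutral here. With a 3.0-fold higher number from compound 1 to compound 3 (0.48 log units; beyond the scatter) on the ring attached through oxygen, both position changes shown raise the number when the group leaves the 4-position of the ring, and neither pair goes against this. Nothing shown here bears on the cause of the step.

Open, from the compounds shown here alone, is whether 4-(trifluoromethyl)phenyl on the amide-type nitrogen would follow the nitrophenyl order. Also open, going by these compounds, is how an amine or a carboxylic acid would compare with nitro on this ring.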